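This account rests on a few compounds, and the source may have more. Where it says the series, first, only, none or still open, it means among the compounds named here.

In an ADME assay on MDBK cells (Bos taurus) for cytotoxicity, read by MTT assay, with a stated time of 96 h (on this read-out lower numbers stand for higher toxicity in this test and higher numbers for lower toxicity in this test), three compounds with a shared core have been tested so far. Compound 1 `CC(=O)c1ccc2[nH]c(-c3ccccc3)nc2c1` gives > 100000 nM, which is a limit of the assay. Compound 2 `C/C(=N\O)c1ccc2[nH]c(-c3ccccc3)nc2c1` gives > 100000 nM, also a limit. Compound 3 `C/C(=N\NC(N)=O)c1ccc2[nH]c(-c3ccccc3)nc2c1` gives > 100000 nM, again a limit. On these numbers compound 3 stands with the other two: the limit of > 100000 nM in this assay, at which 3 of the 3 values shown sit.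

Compound 4 `C/C(=N\NC(N)=S)c1ccc2[nH]c(-c3ccccc3)nc2c1` differs from compound 3 in one place: a group of 3 heavy atoms (1 carbon, 1 nitrogen, 1 sulfur; no ring) in place of a group of 3 heavy atoms (1 carbon, 1 nitrogen, 1 oxygen; no ring), on an amine nitrogen. The measured steps that bear on this change are a step that the two limits leave unreadable from compound 2 to compound 3, a step that the two limits leave unreadable from compound 1 to compound 2 and a step that the two limits leave unreadable from compound 1 to compound 3. None has a readable size, and none swaps oxygen for sulfur, so only a small shift is expected, if any, toward lower numbers. The estimated change is an at least 1.4-fold lower number from compound 3 to compound 4 (0.15 log units; that floor lies within the scatter). For compound 4 the expected value is 70000 nM, with an estimated range from 15000 nM to 100000 nM.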

Compound 4, half-maximal cytotoxic concentration: 32000 nM
Compound 4: the middle estimate sits 2.2-fold (0.34 log units) above what was measured; low and high end bracket the measured number.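

For the compounds shown here, putting sulfur in place of the oxygen of the carbamoyl group on the amine nitrogen gives the first number in this assay that is more than a limit: an at least 3.1-fold lower number from compound 3 to compound 4 (0.49 log units; beyond the scatter). The other two comparisons agree, with an at least 3.1-fold lower number from compound 2 to compound 4 (0.49 log units; beyond the scatter) and an at least 3.1-fold lower number from compound 1 to compound 4 (0.49 log units; beyond the scatter). The steps among compound 1, compound 2 and compound 3 cannot be read, because these compounds share one limit: the limit of > 100000 nM in this assay, at which 3 of the 4 values shown sit.

On these data alone, the true size of the change stays open, since only its minimum can be read. Also open, as far as these compounds go, is whether a longer chain or an amine on that nitrogen would lower the number too, or whether sulfur is needed.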